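This account rests on a few compounds, and the source may have more. Where it says the series, first, only, none or still open, it means among the compounds named here.

In a functional assay on DU-145 cells (Homo sapiens) for inhibition, read by trypan blue exclusion, with a stated time of 96 h (on this read-out higher numbers stand for weaker inhibition of growth and lower numbers for stronger inhibition of growth), compound 1 `COc1ccc(/C=C(/SCc2ccc(Cl)cc2)C(=O)c2ccc(Br)cc2)cc1` gives 10000 nM. Compound 2 `Nc1c(Br)cc(Br)cc1/C=C(\C(=O)c1ccc(Br)cc1)S(=O)(=O)c1ccc(Br)cc1` gives 25000 nM in this assay, the highest of the two numbers and a gap to compound 1 beyond the usual scatter. Compound 3 `O=C(/C(=C\c1ccc(Cl)cc1)S(=O)(=O)c1ccc(Br)cc1)c1ccc(Br)cc1` has not yet been measured. It differs from compound 2 in one place: 4-chlorophenyl in place of 2-amino-3,5-dibromophenyl on a double-bonded chain carbon bound to a double-bonded chain carbon. Among the measured compounds shown here, no measured pair shows this change, so the step is expected to be modest, toward stronger inhibition, a 1.7-fold lower number from compound 2 to compound 3 (0.22 log units; within the scatter), resting only on the weaker result of compound 2 at 25000 nM. Compound 3 is estimated to give 15000 nM, within 5000 nM to 50000 nM.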

Compound 3, concentration for 50% growth inhibition: 50000 nM
Compound 3: middle estimate off by 3.3-fold (0.52 log units), on the low side, within the range that was stated.
By their numbers in this assay, from the lowest: compound 1; then compounds 2 and 3 (each within the scatter of the next).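

In this assay, the exchange of 2-amino-3,5-dibromophenyl for 4-chlorophenyl on a double-bonded chain carbon bound to a double-bonded chain carbon gives a 2.0-fold higher number from compound 2 to compound 3 (0.30 log units; within the scatter). This first reading at this position therefore does not separate compound 2 from compound 3, and neither aryl group stands out there. Nothing at hand accounts for this result.

As far as these compounds go, since the amino group, both bromines and the chlorine all change in this one step, their separate contributions stay open. So does the outcome with a carboxylic acid or a pyridine ring in this place.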